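Swapping the anilide ring on a shared core

The source may report more compounds than this note shows. Statements on the series, on what has been measured and on what is new or still open speak of the compounds shown alone.

Measured so far in a functional assay on A549 cells (Homo sapiens) for cytotoxicity, read by MTT assay, with a stated time of 72 h; on this read-out lower numbers stand for stronger inhibition and higher numbers for weaker inhibition:
compound 1 `O=C(CN1CCN(c2nnc(Cc3ccncc3)c3ccccc23)CC1)Nc1cccc(F)c1` gives 4600 nM
compound 2 `Cc1ccccc1NC(=O)CN1CCN(c2nnc(Cc3ccncc3)c3ccccc23)CC1` gives 43100 nM
compound 3 `O=C(CN1CCN(c2nnc(Cc3ccncc3)c3ccccc23)CC1)Nc1cc(C(F)(F)F)ccc1Cl` gives 1850 nM

Compound 3 stands lowest of the three: a 2.5-fold lower number from compound 1 to compound 3 (0.40 log units; beyond the scatter) and a 23-fold lower number from compound 2 to compound 3 (1.37 log units; beyond the scatter). Compound 4 `COc1ccc(NC(=O)CN2CCN(c3nnc(Cc4ccncc4)c4ccccc34)CC2)cc1OC` is not yet measured; it differs from compound 3 by 3,4-dimethoxyphenyl in place of 2-chloro-5-(trifluoromethyl)phenyl on an amide-type nitrogen. Every measured step changes the same ring on the amide-type nitrogen, and the spread between them is wide: a 9.4-fold higher number from compound 1 to compound 2 (0.97 log units; beyond the scatter) against a 23-fold lower number from compound 2 to compound 3 (1.37 log units; beyond the scatter). Going by the values given here, no measured compound carries 3,4-dimethoxyphenyl, so the direction is uncertain, but most rings here gave higher numbers than compound 3. A modest upward step, a 3.2-fold higher number from compound 3 to compound 4 (0.51 log units; beyond the scatter), is therefore expected. Compound 4 is estimated at 6000 nM, within 1500 nM to 25000 nM.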

Compound 4, half-maximal inhibitory concentration: 26500 nM
Estimate against measurement, compound 4: 4.4-fold (0.65 log units) below, outside the stated range (above it).
By their numbers in this assay, from the lowest: compound 3; then compound 1; then compounds 4 and 2 (each within the scatter of the next).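

The 3,4-dimethoxyphenyl ring does not keep the lower numbers of the halogen-bearing rings: the change gives a 14-fold higher number from compound 3 to compound 4 (1.16 log units; beyond the scatter) and a 5.8-fold higher number from compound 1 to compound 4 (0.76 log units; beyond the scatter). Against 2-methylphenyl it gives a 1.6-fold lower number from compound 2 to compound 4 (0.21 log units; within the scatter), so among these four compounds, the two rings without halogen sit together at the high end, with no exception. No evidence is available on why these rings differ. Still open, as far as these compounds go, is whether a single methoxy group on the phenyl ring would behave like the pair, and whether a saturated cyclohexyl ring could take the same place on the amide-type nitrogen.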